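The source may report more compounds than this note shows. Statements on the series, on what has been measured and on what is new or still open speak of the compounds shown alone.

Compound 1 `Nc1cccc(-c2cn3nc(-c4cccs4)sc3n2)c1` is tested in a functional assay on CCRF-CEM cells (Homo sapiens) for inhibition, read by cell counting, with a stated time of 3 days (on this read-out higher numbers stand for weaker inhibition and lower numbers for stronger inhibition), where compound 1 gives > 250000 nM, which is a limit of the assay and not a number. Compound 1 thus sits at the limit of > 250000 nM in this assay, at which 1 of the 3 values shown sits. Compound 3 `C=C(Br)C(=O)Nc1cccc(-c2cn3nc(-c4cccs4)sc3n2)c1` gives 410 nM in this assay, and the step is an at least 600-fold lower number from compound 1 to compound 3 (2.78 log units; beyond the scatter). Compound 2 `C=C(Br)C(=O)Nc1cccc(-c2cn3nc(Cc4cccc(OC)c4)sc3n2)c1` gives 3100 nM in this assay, and the step is a 7.6-fold lower number from compound 2 to compound 3 (0.88 log units; beyond the scatter). Compound 4 `Cc1ccc(-c2nn3cc(-c4cccc(N)c4)nc3s2)cc1` differs from compound 1 by 4-methylphenyl in place of thiophen-2-yl on an aromatic carbon. Within the data shown here, no measured step covers this exchange directly: the only measured replacement of the thiophen-2-yl, a 7.6-fold lower number from compound 2 to compound 3 (0.88 log units; beyond the scatter), was modest, whereas the large step of an at least 600-fold lower number from compound 1 to compound 3 (2.78 log units; beyond the scatter) involved the (1-bromoethenyl)carbonyl, which compound 4 does not carry. Compound 4 is therefore expected to stay at the limit, with a number no higher from compound 1 to compound 4 (the limit leaves the size open) as the expected step. The estimate for compound 4 in this assay is 250000 nM, between 50000 nM and 300000 nM.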

Compound 4, half-maximal inhibitory concentration: 5900 nM
Compound 4: middle estimate off by 42-fold (1.63 log units), on the high side, and the stated range ends above it.
By their numbers in this assay, from the lowest: compound 3; then compounds 2 and 4 (each within the scatter of the next). At a limit, above all of these: compound 1.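

In this assay, 4-methylphenyl in place of thiophen-2-yl on this aromatic carbon gives an at least 42-fold lower number from compound 1 to compound 4 (1.62 log units; beyond the scatter). The earlier compounds shown here showed a large step only with the (1-bromoethenyl)carbonyl on the nitrogen, whereas this change at the carbon next to the ring nitrogen and the ring sulfur also gives a large step with that nitrogen unacylated. The true size of the step stays open, as the value of compound 1 is a limit and not a number: the limit of > 250000 nM in this assay, at which 1 of the 4 values shown sits.

The compounds shown leave open whether the methyl or the six-membered ring carries the change, which a plain phenyl would help to separate. They also leave open how a 4-methoxyphenyl or a 4-chlorophenyl would behave at this carbon.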